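Swapping the Aryl Group on the Hydrazone Carbon

A few compounds are considered here, and "the series" means these few. Any claim that something is new, unique, unknown or untested is made for them only; others in the source may bear on it.

Of the compounds shown here, three sharing one core have been tested in a functional assay on MKN-45 cells (Homo sapiens) for cytotoxicity, read by MTT assay, with a stated time of 72 h; a lower number here means a stronger inhibitor, a higher number a weaker inhibitor. Compound 1 `CN(C)CCn1cnnc1-c1cc(Oc2ccc(NC(=O)N/N=C/c3ccc(F)cc3Cl)cc2F)ccn1` gives 870 nM. Compound 2 `CN(C)CCn1cnnc1-c1cc(Oc2ccc(NC(=O)N/N=C/c3ccc(O)c(O)c3)cc2F)ccn1` gives 3240 nM. Compound 3 `CN(C)CCn1cnnc1-c1cc(Oc2ccc(NC(=O)N/N=C/c3ccc(O)c(Br)c3)cc2F)ccn1` gives 1860 nM. Compound 3 stands second highest of the three numbers: the step of a 2.1-fold higher number from compound 1 to compound 3 (0.33 log units; beyond the scatter) is beyond the scatter, while the step of a 1.7-fold lower number from compound 2 to compound 3 (0.24 log units; within the scatter) is within it, so compound 2 and compound 3 cannot be told apart.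

Compound 4 `Cc1cc(/C=N/NC(=O)Nc2ccc(Oc3ccnc(-c4nncn4CCN(C)C)c3)c(F)c2)cc(C)c1O` differs from compound 3 in one place: 4-hydroxy-3,5-dimethylphenyl in place of 3-bromo-4-hydroxyphenyl on a carbon with a double bond to nitrogen

Among the compounds with values here, the steps that bear on this change are the two that also alter the group on the carbon with a double bond to nitrogen. The step of a 2.1-fold higher number from compound 1 to compound 3 (0.33 log units; beyond the scatter) and the step of a 3.7-fold higher number from compound 1 to compound 2 (0.57 log units; beyond the scatter) were modest, and the step of a 1.7-fold lower number from compound 2 to compound 3 (0.24 log units; within the scatter) was within the scatter. Keeping the hydroxy and exchanging only the other ring substituents is therefore expected to move this assay little, if at all, for compound 4. Compound 4 is estimated at 1900 nM, within 700 nM to 5000 nM, an expected step of a 1.0-fold higher number from compound 3 to compound 4 (0.01 log units; within the scatter).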

Compound 4, half-maximal inhibitory concentration: 1510 nM
The estimate for compound 4 lay 1.3-fold (0.10 log units) above the measured number; the range from low to high includes it.
By their numbers in this assay, from the lowest: compounds 1, 4, 3 and 2 (each within the scatter of the next, the first and the last beyond it).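

In this assay the change of ring gives a 1.2-fold lower number from compound 3 to compound 4 (0.09 log units; within the scatter) and so shows that 4-hydroxy-3,5-dimethylphenyl on this carbon cannot be told apart from 3-bromo-4-hydroxyphenyl. It also gives a 2.1-fold lower number from compound 2 to compound 4 (0.33 log units; beyond the scatter) and thereby separates a ring from 3,4-dihydroxyphenyl, which compound 3 could not do. The third new step is a 1.7-fold higher number from compound 1 to compound 4 (0.24 log units; within the scatter) and places compound 4 closer to compound 1 than the printed steps place compound 2 or compound 3, since only compound 4 stays within the scatter of the 2-chloro-4-fluorophenyl compound.

The compounds shown leave open whether an amino group or a carboxylic acid in place of the hydroxy on this ring would keep the number in the same range. No measurement here gives a reason for any of these steps.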